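This account rests on a few compounds, and the source may have more. Where it says the series, first, only, none or still open, it means among the compounds named here.

Compound 3 `c1ccc(Cc2ccc3c(NCCCNCc4ccco4)ccnc3c2)cc1` sits in a physicochemical assay for solubility, with a stated time of 18 h, at pH 7.4 (a higher number here means a more soluble compound, a lower number a less soluble compound), at 4200 nM. Two close relatives share its core: compound 1 `Cc1cc(C)cc(Cc2ccc3c(NCCCNCc4ccco4)ccnc3c2)c1` gives 4200 nM in this assay, and compound 2 `Fc1ccc(Cc2ccc3c(NCCCNCc4ccco4)ccnc3c2)cc1` gives 4200 nM. The three values are level at the digits shown, so compound 3 is neither more nor less soluble than its neighbours within the scatter; no change at the digits printed from compound 1 to compound 3 (within the scatter), no change at the digits printed from compound 2 to compound 3 (within the scatter), and no change at the digits printed from compound 1 to compound 2 (within the scatter).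

Compound 4 `c1coc(CNCCCNc2ccnc3cc(-c4cccc5ccccc45)ccc23)c1` is the next structure: naphthalen-1-yl in place of benzyl on an aromatic carbon. Within the data shown here, none of the measured steps tries this kind of change. Each of them only alters what hangs on the phenyl ring of a benzyl group, swapping 3,5-dimethylphenyl, 4-fluorophenyl and plain phenyl, and each left this assay unchanged. Here the benzyl itself leaves, and a larger naphthalen-1-yl of 10 carbon atoms with two fused aromatic rings attaches directly to the core. That is a bigger change than anything measured, so the flat pattern among compounds 1, 2 and 3 is only a weak guide. A modest fall in solubility is expected, a step of a 1.9-fold lower number from compound 3 to compound 4 (0.28 log units; within the scatter) in this assay, though it may well stay within the scatter. Compound 4 is estimated at 2200 nM, with a range from 700 nM to 5500 nM.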

Compound 4, solubility: 32000 nM
Compound 4: middle estimate off by 15-fold (1.16 log units), on the low side; the measured number lies above the stated range.
By their numbers in this assay, from the lowest: compounds 1, 2 and 3 (each within the scatter of the next); then compound 4.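

In this assay, putting naphthalen-1-yl in place of the benzyl on the aromatic carbon gives a 7.6-fold higher number from compound 3 to compound 4 (0.88 log units; beyond the scatter); the substituted benzyl compounds show the same size of step, a 7.6-fold higher number from compound 2 to compound 4 (0.88 log units; beyond the scatter) and a 7.6-fold higher number from compound 1 to compound 4 (0.88 log units; beyond the scatter). This position can therefore affect the read-out: changing only what hangs on the phenyl ring of the benzyl left the number level, whereas replacing the whole benzyl moves it beyond the scatter, and upward, even though the entering group is the larger, with 10 heavy atoms against 7. No measurement shown here explains this rise.

The change removes the saturated carbon of the benzyl and also brings in a second fused aromatic ring, and these compounds cannot separate those two differences. A phenyl group attached directly to the aromatic carbon would sit one step from both compound 3 and compound 4, and naphthalen-2-yl would show whether the rise depends on how the two-ring group is attached.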